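Thiophene in Place of the Substituted Phenyl on a Sulfonamide

The source may hold more compounds than are shown below. What is called first, only, known or untested is meant among the compounds shown, and "the series" means these compounds.

Measured compounds:
compound 1 `COc1cc2nc(N3CCCC3)nc(NS(=O)(=O)C3CC3)c2cc1OC`: 10.2 ug/mL
compound 2 `COc1cc2nc(Cl)nc(NS(=O)(=O)c3cccc(C(F)(F)F)c3)c2cc1OC`: 99 ug/mL
compound 3 `COc1ccc(S(=O)(=O)Nc2nc(Cl)nc3cc(OC)c(OC)cc23)cc1C`: 57 ug/mL

Of the compounds shown here, three sharing one core have been tested in a functional assay on COLO 205 cells (Homo sapiens) for cytotoxicity, read by MTT assay, with a stated time of 24 h; a higher number here means a weaker inhibitor, a lower number a stronger inhibitor. Compound 3 stands second highest of the three numbers. Its nearest neighbour is compound 2, whose number is higher, though the gap between them is within the scatter, so no order can be read between compound 2 and compound 3. Compound 1 lies furthest away, with a number lower than that of compound 3 by a margin beyond the scatter.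

The next compound, compound 4 `COc1cc2nc(Cl)nc(NS(=O)(=O)c3cccs3)c2cc1OC`, has not yet been measured in this assay. The change from compound 3 is thiophen-2-yl in place of 4-methoxy-3-methylphenyl on a sulfonyl sulfur. For the measured compounds named here, no pair of measured compounds differs in only one place, so no measured step guides the expectation. Compound 4 is expected to give 60 ug/mL, within 25 ug/mL to 150 ug/mL. The expected step of a 1.1-fold higher number from compound 3 to compound 4 (0.02 log units; within the scatter) is estimated to stay within the scatter, in neither direction beyond it.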

Compound 4, half-maximal inhibitory concentration: 27.5 ug/mL
The estimate for compound 4 lay 2.2-fold (0.34 log units) above the measured number; the measured number falls inside the stated range.
By their numbers in this assay, from the lowest: compound 1; then compound 4; then compounds 3 and 2 (each within the scatter of the next).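

In this assay, for the compounds shown here, the change on the sulfonyl sulfur gives the first reading of a single-place difference in this set: thiophen-2-yl in place of 4-methoxy-3-methylphenyl brings a 2.1-fold lower number from compound 3 to compound 4 (0.32 log units; beyond the scatter), a modest step. So at this position, a five-membered aromatic ring with one hetero atom is compatible with a lower number than the substituted phenyl of compound 3. Nothing on hand explains the step.

Going by these compounds alone, the single step cannot separate the ring swap from the loss of the methoxy and methyl groups, and an unsubstituted phenyl or a furan-2-yl on the sulfonyl sulfur would bear on that. From the compounds shown here alone, it also remains open how a simple alkyl chain such as n-butyl on the sulfonyl sulfur would compare with thiophen-2-yl.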